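Halophenyl Swap on the Urea Nitrogen: Compound 2 to Compound 3

This account rests on a few compounds, and the source may have more. Where it says the series, first, only, none or still open, it means among the compounds named here.

Compound 1: `COc1ccccc1NC(=O)Nc1cccc(CNc2ncnc3cc(OC)c(OC)cc23)c1` — 15200 nM
Compound 2: `COc1cc2ncnc(NCc3cccc(NC(=O)Nc4ccc(F)cc4)c3)c2cc1OC` — 16900 nM

In a functional assay on A549 cells (Homo sapiens) for antiproliferative activity, read by MTT assay (a lower number here means a stronger inhibitor, a higher number a weaker inhibitor), compound 1 gives 15200 nM and compound 2 gives 16900 nM. Within the data shown here, the one step between them, a 1.1-fold higher number from compound 1 to compound 2 (0.05 log units; within the scatter), is within the scatter, so compound 2 stands alongside compound 1 with no difference that can be read. Compound 3, `COc1cc2ncnc(NCc3cccc(NC(=O)Nc4ccccc4Cl)c3)c2cc1OC`, differs from compound 2 by 2-chlorophenyl in place of 4-fluorophenyl on an amide-type nitrogen. That earlier step, a 1.1-fold higher number from compound 1 to compound 2 (0.05 log units; within the scatter), also exchanged one ring on this nitrogen for another without moving the number beyond the scatter. With nothing else to go on, compound 3 is expected to show a 1.0-fold higher number from compound 2 to compound 3 (0.00 log units; within the scatter). The estimate for compound 3 is 17000 nM, with a range from 8000 nM to 36000 nM.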

Compound 3, half-maximal inhibitory concentration: 15200 nM
The estimate for compound 3 lay 1.1-fold (0.05 log units) above the measured number; the range from low to high includes it.
By their numbers in this assay, from the lowest: compounds 1, 3 and 2 (each within the scatter of the next).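

In this assay, 2-chlorophenyl in place of 4-fluorophenyl on the amide-type nitrogen gives a 1.1-fold lower number from compound 2 to compound 3 (0.05 log units; within the scatter), and chloro in place of methoxy on an aromatic carbon gives no change at the digits printed from compound 1 to compound 3 (within the scatter). A chlorine-bearing ring thus joins the fluorine- and methoxy-bearing rings on this nitrogen, and none of the three compounds can be told apart from the others by its number. Nothing at hand accounts for this sameness. The compounds shown leave open whether a ring carrying an amine or a carboxylic acid, or a longer alkyl chain in place of the ring, would move the number beyond the scatter.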